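The source may hold more compounds than are shown below. What is called first, only, known or untested is meant among the compounds shown, and "the series" means these compounds.

Compound 3 `O=C(O)Cc1sc(C(c2ccc(F)cc2)c2ccc(F)cc2)nc1-c1ccoc1` gives 14 nM in an in vitro assay on HEK385-7 cells for displacement of a labelled ligand from prostaglandin D2 receptor 2 (Homo sapiens) (a lower number here means a stronger inhibitor, a higher number a weaker inhibitor), and so stands second highest of the three numbers measured. Compound 1 `O=C(O)Cc1sc(C(c2ccc(F)cc2)c2ccc(F)cc2)nc1-c1cccc(F)c1` gives 1.4 nM in this assay, and compound 2 `CS(=O)(=O)Nc1cccc(-c2nc(C(c3ccc(F)cc3)c3ccc(F)cc3)sc2CC(=O)O)c1` gives 40 nM. The two steps that reach compound 3 are a 10-fold higher number from compound 1 to compound 3 (1.00 log units; beyond the scatter) and a 2.9-fold lower number from compound 2 to compound 3 (0.46 log units; beyond the scatter); the remaining step is a 29-fold higher number from compound 1 to compound 2 (1.46 log units; beyond the scatter).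

Compound 4 `O=C(O)Cc1sc(C(c2ccc(F)cc2)c2ccc(F)cc2)nc1-c1cc(F)nc(F)c1` differs from compound 3 in one place: 2,6-difluoropyridin-4-yl in place of furan-3-yl on an aromatic carbon. The change returns to a six-membered aromatic ring at the place where compound 1 carries 3-fluorophenyl, and compound 1 holds the lowest number of the set with 1.4 nM. Among the compounds with values here, the step of a 10-fold higher number from compound 1 to compound 3 (1.00 log units; beyond the scatter) bears most directly on it, since it shows what leaving a six-membered ring for furan-3-yl cost; the new ring carries two fluorines and a ring nitrogen, for which no measured step exists. A modest lowering in this assay is therefore expected, though not to the level of compound 1. Compound 4 is expected to give 4 nM, between 1.5 nM and 12 nM, an estimated step of a 3.5-fold lower number from compound 3 to compound 4 (0.54 log units; beyond the scatter).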

Compound 4, half-maximal inhibitory concentration: 5.4 nM
For compound 4 the middle estimate is 1.4-fold (0.13 log units) below the measured one, within the range that was stated.
By their numbers in this assay, from the lowest: compound 1; then compound 4; then compound 3; then compound 2.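

In this assay, the step of a 2.6-fold lower number from compound 3 to compound 4 (0.41 log units; beyond the scatter) shows that at this place, on the aromatic carbon next to the ring nitrogen, a six-membered aromatic ring carrying a ring nitrogen and two fluorines gives a lower number than furan-3-yl. This ring does not match 3-fluorophenyl, as the step of a 3.9-fold higher number from compound 1 to compound 4 (0.59 log units; beyond the scatter) shows, but it lies clearly below 3-(methanesulfonamido)phenyl, with the step of a 7.4-fold lower number from compound 2 to compound 4 (0.87 log units; beyond the scatter). There is no evidence available that explains any of these differences.

The compounds shown leave open how much of the change belongs to the ring size, the ring nitrogen or the two fluorines. An unsubstituted pyridin-4-yl and a 3,5-difluorophenyl group at this place would pull those parts apart.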